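A few compounds are considered here, and "the series" means these few. Any claim that something is new, unique, unknown or untested is made for them only; others in the source may bear on it.

Measured compounds in a physicochemical assay for lipophilicity, read by HPLC, measured as octanol-water partition, at pH 7.4; a higher number here means a more lipophilic compound, a lower number a more polar compound: compound 1 `c1ccc2c3c(ccc2c1)CCC1(CCN(CCC2CCCCC2)CC1)O3` gives 4.74; compound 2 `OC1CC2(CCN(CCC3CCCCC3)CC2)Oc2c1ccc1ccccc21` gives 3.54; compound 3 `O=C1CC2(CCNCC2)Oc2c1ccc1ccccc21` gives 1.78.

Compound 3 stands lowest of the three, with compound 2 nearest and compound 1 furthest. For the measured compounds named here, the one measured step, a number 1.20 log units lower from compound 1 to compound 2 (beyond the scatter), concerns a change elsewhere in the core and does not bear on the step to compound 4 `O=C1CC2(CCN(CCC3CCCCC3)CC2)Oc2c1ccc1ccccc21`, which carries 2-cyclohexylethyl in place of hydrogen on an amine nitrogen in a ring. Going by the values given here, no measured pair isolates this change; compound 2 and compound 3 differ in two places, and their values in this assay stand far apart. A large upward step a number 2.12 log units higher from compound 3 to compound 4 (beyond the scatter) is therefore expected. Compound 4 is estimated at 3.9, with a range of 3.3 to 4.5.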

Compound 4, distribution coefficient: 4.5
Compound 4: middle estimate off by 0.60 log units, on the low side; measured number inside the range.
By their numbers in this assay, from the lowest: compound 3; then compound 2; then compounds 4 and 1 (each within the scatter of the next).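

For the compounds shown here, on the amine nitrogen in the ring, 2-cyclohexylethyl in place of hydrogen gives, in this assay, a large rise of a number 2.72 log units higher from compound 3 to compound 4 (beyond the scatter) on the ketone core, the first measured step at this position. The earlier compounds shown here gave no clean reading of this change, since compound 2 and compound 3 differ in two places. Nothing available accounts for the size of this step.

As far as these compounds go, whether a shorter group on this nitrogen, such as methyl or benzyl, gives a proportionate step remains open. So does whether an amide at this nitrogen behaves like the amine.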